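Pyrrolidinylethyl in place of acetyl on the ring nitrogen

This account rests on a few compounds, and the source may have more. Where it says the series, first, only, none or still open, it means among the compounds named here.

Measured so far:
compound 1, `Cc1nn(C)c2c1C(c1ccccc1)=NCCN2`: 2.5 mg/kg
compound 2, `CC(=O)N1CCN=C(c2cccc(Cl)c2)c2c(C)nn(C)c21`: > 10 mg/kg

The assay is a functional assay on the whole organism for positive allosteric modulation, with Rattus norvegicus as the target; a lower number here means that less compound is needed, a higher number that more compound is needed for the effect. In it compound 1, built on the shared core with a phenyl group, gives 2.5 mg/kg. Compound 2 carries a 3-chlorophenyl group and an acetyl on the ring nitrogen; for compound 2 the assay reports only a limit, > 10 mg/kg, and not a number. This is the point from which the next step sets out, (the limit of > 10 mg/kg in this assay, at which 1 of the 2 values shown sits), so the distance to any lower value is not known. Among the measured compounds shown here, the two compounds differ in more than one place, and their values show only that compound 1 gives a number where compound 2 gives a limit.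

Compound 3, `Cc1nn(C)c2c1C(c1cccc(Cl)c1)=NCCN2CCN1CCCC1`, keeps the 3-chlorophenyl group of compound 2 and changes only the ring nitrogen: 2-(pyrrolidin-1-yl)ethyl in place of acetyl on a nitrogen on an aromatic ring in a ring. For the measured compounds named here, no measured step of this kind is available, so the expectation rests on compound 1 alone, which without the acetyl gives 2.5 mg/kg. Compound 3 is expected to need a dose near that of compound 1; the step of an at least 2.0-fold lower number from compound 2 to compound 3 (0.30 log units; that floor lies within the scatter) is expected to run toward less compound, beyond the scatter, since it leaves a limit. Compound 3 is estimated at 5 mg/kg, within 1.5 mg/kg to 15 mg/kg.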

Compound 3, minimum effective dose: > 10 mg/kg
Compound 3 gave a limit, no number; the forecaster's own chance of this, stated with the estimate: 30%; at least 2.0-fold (0.30 log units) between middle value and limit.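

In this assay, compound 2 and compound 3 each give only a limit and not a number, so no step can be read between them: the limit of > 10 mg/kg in this assay, at which 2 of the 3 values shown sit.

The compounds shown leave open how far apart compound 2 and compound 3 lie, and whether 2-(pyrrolidin-1-yl)ethyl in place of acetyl changes the dose needed at all.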